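From a free amino group to cyclopropylamino

The compounds below may be only part of what the source reports. "The series", "measured", "known", "first", "only" and "open" are said of these compounds alone.

Values measured so far in a functional assay on KB cells (Homo sapiens) for inhibition (on this read-out higher numbers stand for weaker inhibition and lower numbers for stronger inhibition), are these
- compound 1 `Nc1nc2cc(Cl)c(Cl)cc2n1Cc1ccccc1` gives 170000 nM as its value
- compound 2 `Cc1cccc(Cn2c(N)nc3cc(Cl)c(Cl)cc32)c1` gives 65000 nM as its value
- compound 3 `Nc1nc2cc(Cl)c(Cl)cc2n1Cc1ccc([N+](=O)[O-])cc1` gives 35000 nM as its value

Compound 1 stands highest of the three, which makes it the weakest inhibitor measured so far. Both other compounds lie beyond the scatter from it.

Compound 4 `Clc1cc2nc(NC3CC3)n(Cc3ccccc3)c2cc1Cl` has not yet been measured. Its difference from compound 1 is cyclopropyl in place of hydrogen on a nitrogen on an aromatic ring, so amino becomes cyclopropylamino.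

Two measured steps start from compound 1. Methyl in place of hydrogen on an aromatic carbon gave a modest change (a 2.6-fold lower number from compound 1 to compound 2 (0.42 log units; beyond the scatter)), and nitro in place of hydrogen on an aromatic carbon gave another (a 4.9-fold lower number from compound 1 to compound 3 (0.69 log units; beyond the scatter)). For the measured compounds named here, both changes sit on an aromatic carbon, and no measured compound carries a change on that nitrogen, so they offer only indirect guidance. They do show that small additions to compound 1 have so far brought modest moves towards lower numbers, and a similar move is expected here, although a step to a higher number cannot be ruled out.

The estimated change is modest (a 2.4-fold lower number from compound 1 to compound 4 (0.39 log units; beyond the scatter)).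

Compound 4 is expected at 70000 nM with 20000 nM as the estimated lower end and 220000 nM as the upper end.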

Compound 4, half-maximal inhibitory concentration: 60000 nM
Compound 4: the middle estimate sits 1.2-fold (0.07 log units) above what was measured; the measured number falls inside the stated range.
By their numbers in this assay, from the lowest: compounds 3, 4 and 2 (each within the scatter of the next); then compound 1.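

In this assay, putting cyclopropyl in place of a hydrogen on the amino nitrogen gives a 2.8-fold lower number from compound 1 to compound 4 (0.45 log units; beyond the scatter), a modest step that lies beyond the usual scatter. This is the first change shown on that nitrogen, as the earlier steps both sat on an aromatic carbon, and it shows that this nitrogen can carry a three-membered carbon ring while the number still moves down rather than up. Nothing available accounts for this drop, so the step stands as an observation with no known cause.

With cyclopropyl as the only group shown on this nitrogen, it remains open whether the ring itself matters or whether another carbon group, such as ethyl, cyclobutyl or a longer chain like n-butyl, would give a similar step. Going by these compounds, it also remains open whether cyclopropylamino would add to the step seen with the nitro group of compound 3 if both stood on one molecule, and whether an acetyl group on the nitrogen would move the number the same way.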